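This account rests on a few compounds, and the source may have more. Where it says the series, first, only, none or still open, it means among the compounds named here.

Notes on the series. Compound 1 `CCCCCCNc1nc(SCc2ccc(C(F)(F)F)cc2)nc2ccccc12`, compound 2 `FC(F)(F)c1ccc(CSc2nc(N3CCCCC3)c3ccccc3n2)cc1` and compound 3 `FC(F)(F)c1ccc(CSc2nc(Nc3ccccc3)c3ccccc3n2)cc1` share one core and differ in a single substituent, and all three were read in a functional assay on MCF7 cells (Homo sapiens) for cytotoxicity, read by MTT assay, with a stated time of 72 h; on this read-out higher numbers stand for weaker inhibition and lower numbers for stronger inhibition. Compound 1 gives 24300 nM. Compound 2 reaches only the limit of the assay, > 50000 nM, and no number. Compound 3 gives 44000 nM. Among the two real numbers compound 3 stands highest, with compound 1 nearest, the gap being a 1.8-fold higher number from compound 1 to compound 3 (0.26 log units; within the scatter) for phenyl in place of hexyl on a nitrogen on an aromatic ring. The other steps are less informative: an at least 2.0-fold higher number from compound 1 to compound 2 (0.31 log units; beyond the scatter) runs into (the limit of > 50000 nM in this assay, at which 1 of the 3 values shown sits), and an at least 1.1-fold lower number from compound 2 to compound 3 (0.05 log units; that floor lies within the scatter) only sets a floor.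

Compound 4 `FC(F)(F)c1ccc(CSc2nc(Nc3ccccc3C(F)(F)F)c3ccccc3n2)cc1` takes the next step from compound 3: trifluoromethyl in place of hydrogen on an aromatic carbon. Among the measured compounds shown here, no measured step touches this phenyl itself. The nearest comparisons are a 1.8-fold higher number from compound 1 to compound 3 (0.26 log units; within the scatter) and an at least 1.1-fold lower number from compound 2 to compound 3 (0.05 log units; that floor lies within the scatter), both within the scatter; the three values sit close together near the limit. The expected step of a 1.0-fold higher number from compound 3 to compound 4 (0.01 log units; within the scatter) is none beyond the scatter, with a real chance that compound 4 also reports only the limit. Compound 4 is estimated at 45000 nM, within 20000 nM to 100000 nM.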

Compound 4, half-maximal inhibitory concentration: > 50000 nM
Compound 4 was reported as a limit; the forecaster's own chance of this, stated with the estimate: 40%; at least 1.1-fold (0.04 log units) between middle value and limit.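

In this assay the trifluoromethyl, on an aromatic carbon ortho to a large group, is the only change shown on the anilino phenyl itself, and it yields no more than a floor that does not clear the scatter: an at least 1.1-fold higher number from compound 3 to compound 4 (0.05 log units; that floor lies within the scatter). The comparison with the hexylamino compound does clear the scatter, which the step from compound 3 alone did not: an at least 2.0-fold higher number from compound 1 to compound 4 (0.31 log units; beyond the scatter). The entry for compound 4 is a limit and not a number, and the step between the piperidin-1-yl and (2-(trifluoromethyl)phenyl)amino compounds cannot be read, so more of the series now carries no real number: the limit of > 50000 nM in this assay, at which 2 of the 4 values shown sit.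

Open, on these data alone, is whether a methoxy group or a fluorine in place of the trifluoromethyl, or a carboxylic acid on the same phenyl, would give a readable number in this assay. Also open, as far as these compounds go, is whether an octyl chain in place of hexyl would shift the value, where compound 1 gives 24300 nM.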